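The source may report more compounds than this note shows. Statements on the series, on what has been measured and on what is new or still open speak of the compounds shown alone.

Measured so far in a functional assay on HCT-116 cells (Homo sapiens) for antiproliferative activity, read by MTT assay, with a stated time of 72 h; a lower number here means a stronger inhibitor, a higher number a weaker inhibitor:
compound 1 `Nc1nc(N)c2cc(CSC(=S)N3CCN(C4CCCCC4)CC3)ccc2n1` gives 8400 nM
compound 2 `Nc1nc(N)c2cc(CSC(=S)N3CCN(c4ccccc4)CC3)ccc2n1` gives 4120 nM
compound 3 `Cc1ccc(N2CCN(C(=S)SCc3ccc4nc(N)nc(N)c4c3)CC2)cc1` gives 5510 nM

Compound 3 stands second highest of the three numbers; the steps of a 1.3-fold higher number from compound 2 to compound 3 (0.13 log units; within the scatter) and a 1.5-fold lower number from compound 1 to compound 3 (0.18 log units; within the scatter) are both within the scatter. Compound 4 `CC(=O)c1ccc(N2CCN(C(=S)SCc3ccc4nc(N)nc(N)c4c3)CC2)cc1` differs from compound 3 by acetyl in place of methyl on an aromatic carbon. For the measured compounds named here, the measured steps that bear on this are the two exchanges at the ring nitrogen, a 2.0-fold lower number from compound 1 to compound 2 (0.31 log units; beyond the scatter) and a 1.5-fold lower number from compound 1 to compound 3 (0.18 log units; within the scatter), and the single change on the aromatic carbon, a 1.3-fold higher number from compound 2 to compound 3 (0.13 log units; within the scatter). Going by the values given here, none of them introduces an acetyl, and the one change at the same aromatic carbon stays within the scatter. Therefore no step beyond the scatter is expected in this assay. Compound 4 is estimated at 5000 nM, range 2500 nM to 10000 nM, which is expected to mean a 1.1-fold lower number from compound 3 to compound 4 (0.04 log units; within the scatter).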

Compound 4, half-maximal inhibitory concentration: 8260 nM
Beside the measured number, compound 4's estimate is 1.7-fold (0.22 log units) below it; the measured number falls inside the stated range.
By their numbers in this assay, from the lowest: compounds 2, 3, 4 and 1 (each within the scatter of the next, the first and the last beyond it).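

In this assay, a group carrying a carbonyl on the aromatic carbon para to a large group gives a 1.5-fold higher number from compound 3 to compound 4 (0.18 log units; within the scatter), so the exchange of methyl for acetyl stays within the scatter. Against hydrogen at that carbon, acetyl gives a 2.0-fold higher number from compound 2 to compound 4 (0.30 log units; within the scatter), also within the scatter. The 4-acetylphenyl group in place of cyclohexyl gives a 1.0-fold lower number from compound 1 to compound 4 (0.01 log units; within the scatter), although the phenyl of compound 2 stood beyond the scatter from compound 1.

On these data alone, whether an amine or a carboxylic acid on that aromatic carbon would give a step beyond the scatter stays open. Nothing at hand accounts for these numbers.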